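This account rests on a few compounds, and the source may have more. Where it says the series, first, only, none or still open, it means among the compounds named here.

The measured compounds:
compound 1, `COc1ccc2cc(C(C)c3nnc4n3N=C(c3ccc(Br)cc3)CS4)ccc2c1`, 11500 nM;
compound 2, `COc1ccc2cc(C(C)c3nnc4n3N=C(c3ccc(Cl)cc3Cl)CS4)ccc2c1`, 14600 nM;
compound 3, `COc1ccc2cc(C(C)c3nnc4n3N=C(c3ccc(Cl)cc3)CS4)ccc2c1`, 10100 nM.

All three were tested in a functional assay on MCF7 cells (Homo sapiens) for inhibition, read by sulforhodamine B assay, with a stated time of 72 h; on this read-out lower numbers stand for stronger inhibition and higher numbers for weaker inhibition. Of the three numbers, compound 3 returned the lowest, but the gaps are slight: a 1.1-fold lower number from compound 1 to compound 3 (0.06 log units; within the scatter) and a 1.4-fold lower number from compound 2 to compound 3 (0.16 log units; within the scatter), both within the scatter, so no real separation among the three can be claimed.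

Compound 4, `COc1ccc2cc(C(C)c3nnc4n3N=C(c3ccc(C(F)(F)F)cc3)CS4)ccc2c1`, has not yet been measured in this assay. It differs from compound 3 by trifluoromethyl in place of chloro on an aromatic carbon; the change sits on an aromatic carbon of a six-membered aromatic ring of carbon only, para to a large group. Among the compounds with values here, the steps that bear on it are those that altered the same ring. Exchanging one halogen for another left the number essentially unchanged, as noted above, and adding a further chloro gave a 1.3-fold higher number from compound 1 to compound 2 (0.10 log units; within the scatter), again within the scatter. Within the data shown here, no measured step exchanges a halogen for trifluoromethyl, so the expectation can only draw on how little the substitution of that ring has mattered so far across compounds 1, 2 and 3.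

Compound 4 is therefore expected to stay close to compound 3, with a 1.0-fold higher number from compound 3 to compound 4 (0.02 log units; within the scatter). The estimate for compound 4 is 10500 nM, with a range from 4000 nM to 27000 nM.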

Compound 4, half-maximal inhibitory concentration: 6900 nM
Beside the measured number, compound 4's estimate is 1.5-fold (0.18 log units) above it; the range from low to high includes it.
By their numbers in this assay, from the lowest: compounds 4, 3, 1 and 2 (each within the scatter of the next, the first and the last beyond it).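

In this assay, within the data shown here, trifluoromethyl on this aromatic carbon, para to a large group, is the only group there that is not a single halogen, yet a 1.5-fold lower number from compound 3 to compound 4 (0.17 log units; within the scatter) and a 1.7-fold lower number from compound 1 to compound 4 (0.22 log units; within the scatter) both stay within the scatter, so with four heavy atoms in place of one it cannot be told apart from chloro or bromo. Among these compounds, the one new step that clears the scatter is a 2.1-fold lower number from compound 2 to compound 4 (0.33 log units; beyond the scatter), which is modest and exchanges 2,4-dichlorophenyl for 4-(trifluoromethyl)phenyl, so it changes two places on the ring at once and cannot be assigned to either of them alone. No measurement is available here that would explain these numbers.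

Going by these compounds, whether a group of another kind at this place, such as an amine, a carboxylic acid or a longer chain, would shift the number clearly beyond the scatter remains open. Also open, on these data alone, is whether changes elsewhere in the shared core would matter more than those on this ring.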